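A few compounds are considered here, and "the series" means these few. Any claim that something is new, unique, unknown or untested is made for them only; others in the source may bear on it.

Compound 1 `CC(C)CN(c1ccc(F)cc1)S(=O)(=O)c1ccc2c(c1)C(O)CC(C1CCOCC1)O2`: 3.39 in a physicochemical assay for lipophilicity, at pH 7.4; on this read-out higher numbers stand for higher lipophilicity and lower numbers for lower lipophilicity
Compound 2 `CCc1ccc(N(CC(C)C)S(=O)(=O)c2ccc3c(c2)C(O)CC(C(C)C2CCOCC2)O3)cc1`: 5.04 in this assay

Of the two measured compounds, compound 1 has the lower value; compound 2 lies well beyond the scatter above it. Compound 3 `CCc1ccc(N(CC(C)C)S(=O)(=O)c2ccc3c(c2)C(O)CC(C2CCOCC2)O3)cc1` has not yet been measured. It differs from compound 1 in one place: ethyl in place of fluoro on an aromatic carbon. Within the data shown here, no measured pair shows this exact change, so the expected size of the step rests on the nature of the change alone. Compound 3 is expected to move upward in this assay, with a step of a number 0.91 log units higher from compound 1 to compound 3 (beyond the scatter) that should exceed the scatter. Compound 3 is thus estimated at 4.3, with a range from 3.9 to 4.8.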

Compound 3, distribution coefficient: 4.12
For compound 3 the middle estimate is 0.18 log units above the measured one; low and high end bracket the measured number.
By their numbers in this assay, from the lowest: compound 1; then compound 3; then compound 2.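

Ethyl in place of fluoro on the aromatic carbon gives a number 0.73 log units higher from compound 1 to compound 3 (beyond the scatter) in this assay, so this position clearly affects the read-out. The saturated side of the molecule affects it too: oxan-4-yl in place of 1-(oxan-4-yl)ethyl gives a number 0.92 log units lower from compound 2 to compound 3 (beyond the scatter). Nothing available explains the origin of either step. Where a methoxy group, a longer chain or an amine on that aromatic carbon would fall relative to fluoro and ethyl remains open. Also open, from the compounds shown here alone, is whether either step would keep its size on another core.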